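Ether side chain swap on the shared core

The compounds below may be only part of what the source reports. "The series", "measured", "known", "first", "only" and "open" are said of these compounds alone.

Within the data shown here, compound 3 `Cc1n[nH]c2nc(-c3ccc(NS(=O)(=O)c4cc(Cl)ccc4F)cc3)nc(OCCC(=O)N(C)C)c12` is the only member of the set with a read number: in an assay for inhibition of serine/threonine-protein kinase Sgk1 (Homo sapiens), with stated times of 30 min and 60 min, in the presence of a further agent that is not named here (on this read-out higher numbers stand for weaker inhibition and lower numbers for stronger inhibition), compound 3 gives 438 nM. Compound 1 `O=C(N[C@@H]1CCNC1)c1cc(-c2ccc(NS(=O)(=O)c3cccc(Cl)c3Cl)cc2)nc2[nH]ncc12` sits at a limit of this assay, (the limit of < 1 nM in this assay, at which 1 of the 3 values shown sits), giving < 1 nM. Compound 2 `CCNC(=O)c1cc(-c2ccc(NS(=O)(=O)c3cccc(Cl)c3Cl)cc2)nc2[nH]ncc12` likewise sits at a limit, (the limit of < 1920 nM in this assay, at which 1 of the 3 values shown sits), giving < 1920 nM. Among the measured compounds shown here, the one measured step, a step that the two limits leave unreadable from compound 1 to compound 2, concerns an amide-type nitrogen and cannot be read between two limits, so no measured step bears on the change at the ether oxygen. Compound 4 `Cc1n[nH]c2nc(-c3ccc(NS(=O)(=O)c4cc(Cl)ccc4F)cc3)nc(OC3CCOCC3)c12` differs from compound 3 by oxan-4-yl in place of 2-(dimethylcarbamoyl)ethyl on an oxygen on an aromatic ring. With nothing informing this change, no shift beyond the scatter is expected, and the estimated step is a 1.1-fold lower number from compound 3 to compound 4 (0.04 log units; within the scatter). Compound 4 is therefore expected to give 400 nM, within 130 nM to 1300 nM.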

Compound 4, half-maximal inhibitory concentration: 14 nM
Compound 4: the middle estimate sits 29-fold (1.46 log units) above what was measured; the whole stated range lies above it.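

In this assay, among these compounds, the group on the oxygen on the aromatic ring clearly matters on the shared core: oxan-4-yl in place of 2-(dimethylcarbamoyl)ethyl gives a 31-fold lower number from compound 3 to compound 4 (1.50 log units; beyond the scatter), the only readable step. The step on the amide-type nitrogen, between two limits, cannot be read, so this position gives the first measured size of a change. Nothing shown accounts for the size of this step.

As far as these compounds go, whether the ring itself or its oxygen carries the step stays open. Also open, from the compounds shown here alone, is how cyclohexyl, with no ring oxygen, or piperidin-4-yl, a ring amine, would read on the same oxygen.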